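A few compounds are considered here, and "the series" means these few. Any claim that something is new, unique, unknown or untested is made for them only; others in the source may bear on it.

Compound 1 `CCN(c1cccc(-c2ccccc2)c1)c1ccc(C#N)c(Cl)c1`: "not determined" (no result reported)
Compound 2 `CCN(c1ccc(C#N)c(Cl)c1)c1cc(-n2ccnc2)ccc1C`: > 30000 nM, a limit and not a number

Both entries come from a functional assay on VCaP cells (Homo sapiens) for antiproliferative activity, read by CCK-8 assay, with a stated time of 6 days; on this read-out higher numbers stand for weaker inhibition and lower numbers for stronger inhibition. Compound 2 stands at the limit of > 30000 nM in this assay, at which 1 of the 2 values shown sits. Going by the values given here, compound 1 has no result, so the series offers no measured pair and no step size to read from.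

The next compound is compound 3 `CCN(c1cccc(-n2ccnc2)c1)c1ccc(C#N)c(Cl)c1`. It has hydrogen in place of methyl on an aromatic carbon, at the place ortho to a large group and para to a 1H-imidazol-1-yl group: hydrogen in place of methyl on an aromatic carbon. The rest of the structure is shared with compound 2.

In this assay no change beyond the scatter is expected, in either direction. This expectation rests on compound 2 alone, whose entry is the limit > 30000 nM. The estimated change is an at least 1.2-fold lower number from compound 2 to compound 3 (0.07 log units; that floor lies within the scatter), which is expected to stay within the scatter. A report of only a limit is about as likely as a number. For compound 3 the estimated value is 25000 nM, with an expected range from 7000 nM to 60000 nM.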

Compound 3, half-maximal inhibitory concentration: > 30000 nM
Compound 3: a limit, no number; the forecaster's own chance of this, stated with the estimate: 55%; middle value at least 1.2-fold (0.07 log units) away from the limit.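

In this assay compound 3 gives > 30000 nM, a limit and not a number. Going by these compounds alone, compound 2 also stands at a limit, and no step between compound 2 and compound 3 can be read. The compounds shown leave open what hydrogen in place of methyl on an aromatic carbon does in this assay, and which change to the shared core would give a number.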